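The source may report more compounds than this note shows. Statements on the series, on what has been measured and on what is new or still open speak of the compounds shown alone.

Measured so far in a functional assay on cells for agonist activity at G-protein coupled receptor 52 (Homo sapiens), read by AlphaScreen and cAMP accumulation, with a stated time of 30 min; a lower number here means that less compound is needed, a higher number that more compound is needed for the effect:
compound 1 `Cc1nc(Cc2cccc(C(F)(F)F)c2)sc1-c1ccc(C(N)=O)cc1`, 220 nM
compound 2 `Cc1nc(Cc2cccc(C(F)(F)F)c2)sc1-c1ccc(C(N)=O)c(C(F)(F)F)c1`, 110 nM
compound 3 `COc1cccc(Cc2nc(C)c(-c3ccc(C(N)=O)c(C)c3)s2)c1`, 160 nM

Compound 3 stands second highest of the three numbers; its nearest neighbour is compound 1, and the gap to compound 1 as well as the gap to compound 2 lies within the scatter, so the three values are not told apart.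

Compound 4 `Cc1cc(-c2sc(Cc3cccc(F)c3)nc2C)ccc1C(N)=O` is the next candidate. Against compound 3 the change is fluoro in place of methoxy on an aromatic carbon, the carbon meta to a large group; cut one bond further out it reads 3-methoxyphenyl to 3-fluorophenyl.

Among the measured compounds shown here, the only measured step, a 2.0-fold lower number from compound 1 to compound 2 (0.30 log units; within the scatter), sits on the other ring and swaps trifluoromethyl for hydrogen; it stays within the scatter and bears on the present change only loosely. Compounds 1 and 3, which differ in two places including a trifluoromethyl against a methoxy on the benzyl ring, also show values within the scatter of each other. No step beyond the scatter is therefore expected for compound 4 in this assay, as a 1.3-fold higher number from compound 3 to compound 4 (0.10 log units; within the scatter).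

Compound 4 is estimated at 200 nM, range 90 nM to 450 nM.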

Compound 4, half-maximal effective concentration: 260 nM
The estimate for compound 4 lay 1.3-fold (0.11 log units) below the measured number; the measured number falls inside the stated range.
By their numbers in this assay, from the lowest: compounds 2, 3, 1 and 4 (each within the scatter of the next, the first and the last beyond it).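

In this assay, among the compounds shown here, the exchange of 3-methoxyphenyl for 3-fluorophenyl gives a 1.6-fold higher number from compound 3 to compound 4 (0.21 log units; within the scatter) and so provides the first one-place reading at this position, on the carbon meta to a large group. Within this pair, fluoro stands in place of methoxy, one heavy atom for two and no hydrogen-bond acceptor for one, without a step that can be told apart from the scatter, a reading that compound 1 and compound 3 could not give as they differ in two places. Nothing at hand accounts for this result.

The compounds shown leave open whether the position tolerates groups of a different kind, such as an amine, a carboxylic acid or a longer chain like butoxy, since methoxy and fluoro alone are compared here in a one-place pair. They also leave open whether the fluoro-for-methoxy result holds on other versions of the shared core, for example with trifluoromethyl rather than methyl on the ring that carries the primary amide.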